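Swapping Benzyloxy for Chloro on a Weak Inhibitor

The compounds below may be only part of what the source reports. "The series", "measured", "known", "first", "only" and "open" are said of these compounds alone.

Of the compounds shown here, two have so far been measured in an assay for inhibition of Tryptophan 2,3-dioxygenase (Homo sapiens), with stated times of 10 min and 60 min; a higher number here means a weaker inhibitor, a lower number a stronger inhibitor. Compound 1 `O=[N+]([O-])c1cc(OCc2ccccc2)ccc1CNc1cc(C(F)(F)F)cc2[nH]ncc12` gives 97000 nM in this assay, the higher of the two numbers, so it is the weaker inhibitor of the pair. Compound 2 `O=[N+]([O-])c1cccc(CNc2cc(C(F)(F)F)cc3[nH]ncc23)c1` gives 5170 nM in this assay, a lower number that lies beyond the usual scatter of repeated measurements. Compound 3 `O=[N+]([O-])c1cc(Cl)ccc1CNc1cc(C(F)(F)F)cc2[nH]ncc12` has not yet been measured. It differs from compound 1 in one place: chloro in place of benzyloxy on an aromatic carbon. The chlorine sits on the ring carbon that is meta to the nitro group and para to a large group. Within the data shown here, no measured pair shows this exact swap, so its size is open. Compound 3 is nevertheless expected to give a lower number than compound 1 because compound 1 starts from 97000 nM. The expected step of a 4.9-fold lower number from compound 1 to compound 3 (0.69 log units; beyond the scatter) is moderate, toward a stronger inhibitor. For compound 3 the estimate is 20000 nM, with a range from 5000 nM to 80000 nM.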

Compound 3, half-maximal inhibitory concentration: 1700 nM
Beside the measured number, compound 3's estimate is 12-fold (1.07 log units) above it, outside the stated range (below it).
By their numbers in this assay, from the lowest: compound 3; then compound 2; then compound 1.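

In this assay, putting chloro in place of benzyloxy gives a 57-fold lower number from compound 1 to compound 3 (1.76 log units; beyond the scatter), so what this ring carbon carries, meta to a nitro group and para to a large group, has a large bearing on the measured number. The group that leaves has 8 heavy atoms, including a six-membered aromatic ring of carbon only, and the group that enters is a single chlorine, so in this one pair the much smaller group goes with the stronger inhibitor. Nothing available here explains why the number falls, so the pair records the size of the change and not its cause. Going by these compounds, with only these two groups compared at this position, it remains open whether chlorine itself matters or whether the loss of benzyloxy accounts for the step. A fluorine, a methoxy group or an amine on the same carbon would help separate those two readings.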